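The compounds below may be only part of what the source reports. "The series", "measured", "known", "first", "only" and "open" are said of these compounds alone.

The measured compounds in a functional assay on CCRF-CEM cells (Homo sapiens) for inhibition, read by sulforhodamine B assay, with a stated time of 48 h; on this read-out higher numbers stand for weaker inhibition of growth and lower numbers for stronger inhibition of growth:

compound 1, `N=C(N)c1ccc(-c2ccc(-c3cc(Cl)cc(Cl)c3)s2)cc1`, gives 1540 nM
compound 2, `N=C(N)c1ccc(-c2ccc(-c3ccc(Cl)cc3)s2)cc1F`, gives 194 nM
compound 3, `COc1cc(OC)cc(-c2ccc(-c3ccc(C(=N)N)c(F)c3)s2)c1`, gives 306 nM

Compound 2 has the lowest of the three numbers in this assay. Its nearest neighbour is compound 3, whose number lies within the scatter of repeated measurements, so the two cannot be ranked against each other; its furthest is compound 1, whose number lies beyond the scatter, so the gap from compound 1 to compound 2 is a real one.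

The unmeasured compound 4, `COc1ccc(-c2ccc(-c3ccc(C(=N)N)c(F)c3)s2)cc1`, differs from compound 2 in a single place: methoxy in place of chloro on an aromatic carbon. Since compound 3, which carries methoxy groups in place of chlorine on the same side of the shared core, gives 306 nM, and compound 2 gives 194 nM, the data suggest that exchanging chloro for methoxy here does not move the number far.

Compound 4 is therefore expected to land close to compound 2, with the step from compound 2 to compound 4 estimated at a 1.5-fold higher number from compound 2 to compound 4 (0.19 log units; within the scatter), a small shift toward a slightly higher number that stays within the scatter. For compound 4 the estimate in this assay is 300 nM, with a range from 120 nM to 750 nM.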

Compound 4, concentration for 50% growth inhibition: 3110 nM
Estimate against measurement, compound 4: 10-fold (1.02 log units) below, and the stated range ends below it.
By their numbers in this assay, from the lowest: compounds 2 and 3 (each within the scatter of the next); then compound 1; then compound 4.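

In this assay, the exchange of chloro for methoxy on an aromatic carbon, para to a large group, is the first change in a single place among these compounds, and it gives a 16-fold higher number from compound 2 to compound 4 (1.20 log units; beyond the scatter). The earlier compounds shown here each differed from one another in more than one place, so they could not isolate this position; this pair shows that growth inhibition here is sensitive to the group it carries, with the weaker inhibition going with methoxy, even though the exchange is a small one in the counts: chloro with 1 heavy atom leaves, and methoxy with 2 heavy atoms and 1 hydrogen-bond acceptor enters. Nothing available here explains why the number rises so far.

The compounds shown leave open whether a methyl, a fluoro or an amine at this position would stay near compound 2 or fall with compound 4. They also leave open whether the same exchange of chloro for methoxy would give a step of this size on a core without the fluorine of compound 2.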